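Swapping nitro for hydroxy on a shared bicyclic core

The source may hold more compounds than are shown below. What is called first, only, known or untested is meant among the compounds shown, and "the series" means these compounds.

In an assay on membranes from HEK293 cells for displacement of a labelled ligand from Neuronal acetylcholine receptor; alpha3/beta4 (Homo sapiens), with a stated time of 5 min (a lower number here means a stronger inhibitor, a higher number a weaker inhibitor), three compounds built on one shared core have been measured. Compound 1 `CN1CCC[C@H]1[C@H]1COc2c(N)cccc2O1` gives 13000 nM. Compound 2 `CN1CCC[C@H]1[C@@H]1COc2cc([N+](=O)[O-])ccc2O1` gives 15000 nM, and compound 3 `CN1CCC[C@H]1[C@H]1COc2cc([N+](=O)[O-])ccc2O1` gives 4800 nM. Compounds 2 and 3 have the same atoms and bonds and differ only in how one stereocentre on a saturated ring carbon is drawn; the step of a 3.1-fold lower number from compound 2 to compound 3 (0.49 log units; beyond the scatter) shows that this alone shifts the number, and the only account that can be given for it is the fact that compounds 2 and 3 differ only in the configuration as drawn. Compound 3 therefore has the lowest number of the three, with compound 1 nearest and compound 2 furthest.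

Compound 4 `CN1CCC[C@H]1[C@H]1COc2cc(O)ccc2O1` has not yet been measured. It differs from compound 3 by hydroxy in place of nitro on an aromatic carbon. Within the data shown here, none of the measured steps concerns a change of this kind: the single recorded step involves configuration alone, and compound 1 differs from compound 3 in more than one respect, so it offers no direct guidance either. With nothing to lean on, the expectation is that compound 4 stays close to compound 3, and the estimated step of a 1.3-fold higher number from compound 3 to compound 4 (0.10 log units; within the scatter) is small, with no confident direction. Compound 4 is thus expected to give 6000 nM in this assay, within a wide range from 1500 nM to 25000 nM.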

Compound 4, inhibition constant: 6000 nM
For compound 4 middle estimate and measured number coincide at the digits printed; the range from low to high includes it.
By their numbers in this assay, from the lowest: compounds 3 and 4 (each within the scatter of the next); then compounds 1 and 2 (each within the scatter of the next).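

Among these compounds, the step of a 1.3-fold higher number from compound 3 to compound 4 (0.10 log units; within the scatter) is the first reading in this assay of a change of group on this aromatic carbon, which is meta to a fused ring and para to a fused ring; the earlier step concerned configuration alone. Nitro, with 3 heavy atoms and 0 hydrogen-bond donors, gives way to hydroxy, with 1 heavy atom and 1 hydrogen-bond donor, yet the two numbers stay within the scatter, so this assay does not separate the two groups at this position on this form of the core. The only fact on record about these compounds concerns configuration and offers no explanation for this result.

The compounds shown do not tell whether an amine, a carboxylic acid or a methoxy group on the same carbon would also leave the number within the scatter of compound 3, or whether any of them would shift it. They also leave open whether hydroxy in place of nitro would give an equally small step in the configuration drawn for compound 2.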